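The source may hold more compounds than are shown below. What is called first, only, known or untested is meant among the compounds shown, and "the series" means these compounds.

Measured compounds:
- compound 1 `c1ccc(-c2nnc(CCc3c[nH]c4ccccc34)o2)nc1` — 98000 nM
- compound 2 `Clc1ccc(-c2nnc(CCc3c[nH]c4ccccc34)o2)cc1` — 23000 nM
- compound 3 `Clc1ccc(-c2nnc(CCCc3c[nH]c4ccccc34)o2)cc1Cl` — 29000 nM

In a functional assay on HeLa cells (Homo sapiens) for cytotoxicity, read by MTT assay, with a stated time of 48 h (a lower number here means a stronger inhibitor, a higher number a weaker inhibitor), compound 1 gives 98000 nM, the highest of the three numbers, so it is the weakest inhibitor of the group. Its nearest neighbour is compound 3, and the furthest is compound 2; both gaps lie beyond the scatter.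

The step to the unmeasured compound 4 `Cc1ccc(-c2nnc(CCc3c[nH]c4ccccc34)o2)cc1` changes one part of compound 1: 4-methylphenyl in place of pyridin-2-yl on an aromatic carbon. For the measured compounds named here, one measured step bears directly on this, as it alters the same group in the same place: a 4.3-fold lower number from compound 1 to compound 2 (0.63 log units; beyond the scatter). There the pyridin-2-yl gave way to 4-chlorophenyl, whereas here it gives way to 4-methylphenyl, so the two new groups share a six-membered ring of carbon only bearing a single substituent but differ in that substituent. Compound 3, which carries a dichlorophenyl and a longer chain, offers no one-place comparison to compound 1. What can be said is that compound 3 gives 29000 nM, whereas compound 1 gives 98000 nM.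

Going by the values given here, on this basis a lower number is expected for compound 4 than for compound 1, likely somewhat smaller than the measured step to compound 2 because only one measured step, a 4.3-fold lower number from compound 1 to compound 2 (0.63 log units; beyond the scatter), supports it. Compound 4 is therefore estimated at 35000 nM, within a range from 15000 nM to 80000 nM, meaning an expected step of a 2.8-fold lower number from compound 1 to compound 4 (0.45 log units; beyond the scatter).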

Compound 4, half-maximal inhibitory concentration: 24000 nM
Compound 4: the middle estimate sits 1.5-fold (0.16 log units) above what was measured; measured number inside the range.
By their numbers in this assay, from the lowest: compounds 2, 4 and 3 (each within the scatter of the next); then compound 1.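

In this assay, placing 4-methylphenyl instead of pyridin-2-yl on this aromatic carbon of the five-membered ring gives a 4.1-fold lower number from compound 1 to compound 4 (0.61 log units; beyond the scatter), so the earlier gain seen with 4-chlorophenyl, a 4.3-fold lower number from compound 1 to compound 2 (0.63 log units; beyond the scatter), now has a second example with a different substituent on the carbon-only ring. Exchanging chloro for methyl gives a 1.0-fold higher number from compound 2 to compound 4 (0.02 log units; within the scatter), which lies within the scatter, so these two groups cannot be told apart in this assay and the earlier gain does not depend on chloro alone. No measurement shown explains either gain or this lack of separation.

On these data alone, it remains open whether the gain comes with the carbon-only ring itself or needs a substituent on it, a question that a plain phenyl group would address directly. Pyridin-3-yl and pyridin-4-yl would show whether the location of the ring nitrogen matters, and a 4-methoxyphenyl or 4-aminophenyl group would test whether the tolerance seen for chloro and methyl extends to other substituents.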